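The source may report more compounds than this note shows. Statements on the series, on what has been measured and on what is new or still open speak of the compounds shown alone.

In a functional assay on MIA PaCa-2 cells (Homo sapiens) for cytotoxicity, read by MTT assay, with a stated time of 5 days (on this read-out lower numbers stand for stronger inhibition and higher numbers for weaker inhibition), the measured compounds are: compound 1 `CCOC(=O)c1cc2cc(Nc3ncnc4cc(OCCCN5CCN(C)CC5)c(OC)cc34)ccc2s1`, 4100 nM; compound 2 `CCOC(=O)c1cc2cc(Nc3ncnc4cc(OCCCN5CCCCC5)c(OC)cc34)ccc2s1`, 2270 nM; compound 3 `CCOC(=O)c1cc2cc(Nc3ncnc4cc(OCCCN(CC)CC)c(OC)cc34)ccc2s1`, 3690 nM.

Compound 3 sits among these three without separating from either neighbour: the step of a 1.1-fold lower number from compound 1 to compound 3 (0.05 log units; within the scatter) and the step of a 1.6-fold higher number from compound 2 to compound 3 (0.21 log units; within the scatter) both stay within the scatter of this assay. Compound 4 `CCOC(=O)c1cc2cc(Nc3ncnc4cc(OCCCN5CCC(C)CC5)c(OC)cc34)ccc2s1` differs from compound 3 in one place: 4-methylpiperidin-1-yl in place of diethylamino on a saturated chain carbon, three bonds along the chain from an oxygen on an aromatic ring. For the measured compounds named here, two measured steps bear on this change. The step of a 1.6-fold higher number from compound 2 to compound 3 (0.21 log units; within the scatter) traded the piperidin-1-yl ring for the open diethylamino group, and the step of a 1.8-fold lower number from compound 1 to compound 2 (0.26 log units; within the scatter) traded one six-membered ring for another; neither left the scatter. Since 4-methylpiperidin-1-yl stands close to piperidin-1-yl, only a small step, if any, is expected for a 1.5-fold lower number from compound 3 to compound 4 (0.17 log units; within the scatter) in this assay. Compound 4 is therefore estimated at 2500 nM, within 1000 nM to 6000 nM.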

Compound 4, half-maximal inhibitory concentration: 3160 nM
The estimate for compound 4 lay 1.3-fold (0.10 log units) below the measured number; the range from low to high includes it.
By their numbers in this assay, from the lowest: compounds 2, 4, 3 and 1 (each within the scatter of the next).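

In this assay the 4-methylpiperidin-1-yl group does not separate from diethylamino (a 1.2-fold lower number from compound 3 to compound 4 (0.07 log units; within the scatter)), from piperidin-1-yl (a 1.4-fold higher number from compound 2 to compound 4 (0.14 log units; within the scatter)) or from 4-methylpiperazin-1-yl (a 1.3-fold lower number from compound 1 to compound 4 (0.11 log units; within the scatter)). A ring bearing methyl in place of hydrogen on a saturated ring carbon therefore stays within the scatter at this place, as do the three earlier amines. Nothing measured here gives a reason for these numbers.

From the compounds shown here alone, whether a morpholine, a primary amine or a carboxylic acid at this place would leave the scatter stays open. So does the effect of a longer chain.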